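A few compounds are considered here, and "the series" means these few. Any claim that something is new, unique, unknown or untested is made for them only; others in the source may bear on it.

The study concerns three measured compounds and one that is still to be tested. Compound 1 `CC1(C)CC(NC(=O)Nc2cccc(C#N)c2)c2cc(NS(C)(=O)=O)ccc2O1` and compound 2 `CC1(C)CC(NC(=O)Nc2ccc(C#N)cc2)c2cc(NS(C)(=O)=O)ccc2O1` share one core; compound 3 `CCS(=O)(=O)Nc1ccc2c(c1)C(NC(=S)Nc1cccc(C#N)c1)CC(C)(C)O2` and the unmeasured compound 4 `CCS(=O)(=O)Nc1ccc2c(c1)C(NC(=S)Nc1ccc(C#N)cc1)CC(C)(C)O2` share another. The difference between the two cores is not broken down here.

In a functional assay on thoracic aorta (Rattus norvegicus) for inhibition (a higher number here means that more compound is needed for the effect, a lower number that less compound is needed), compound 1 gives 9300 nM. In this assay compound 2 gives 19800 nM, and compound 3 gives 12100 nM. The values of compound 3 and compound 1 lie within the scatter of each other, as do those of compound 3 and compound 2.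

The change from compound 1 to compound 2 is 4-cyanophenyl in place of 3-cyanophenyl on an amide-type nitrogen. It brought a 2.1-fold higher number from compound 1 to compound 2 (0.33 log units; beyond the scatter). The change from compound 3 to compound 4 is 4-cyanophenyl in place of 3-cyanophenyl on an amide-type nitrogen. The two changes are the same kind of change, but the place differs: in the first the amide-type nitrogen has a carbonyl carbon as its other neighbour, in the second a thiocarbonyl carbon.

Among the measured compounds shown here, for compound 4 a step of about a 2.0-fold higher number from compound 3 to compound 4 (0.30 log units; within the scatter) is expected, close to the earlier one, because the only measured instance of this change is a 2.1-fold higher number from compound 1 to compound 2 (0.33 log units; beyond the scatter), and because compound 3 starts from 12100 nM. Compound 4 is therefore estimated to give 24000 nM in this assay, with a range from 11000 nM to 55000 nM.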

Compound 4, half-maximal effective concentration: 12000 nM
Compound 4: middle estimate off by 2.0-fold (0.30 log units), on the high side; low and high end bracket the measured number.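

In this assay, moving the nitrile from 3-cyanophenyl to 4-cyanophenyl on the amide-type nitrogen whose other neighbour is a thiocarbonyl carbon gives a 1.0-fold lower number from compound 3 to compound 4 (0.00 log units; within the scatter), so on this core the two cyanophenyl groups cannot be told apart. Set beside the same change on the core with a carbonyl carbon at that place, the two steps do not differ by more than the scatter of two such steps allows: the same change on two cores in this assay, a 2.1-fold higher number (0.33 log units; beyond the scatter) from compound 1 to compound 2 and a 1.0-fold lower number (0.00 log units; within the scatter) from compound 3 to compound 4, 2.1-fold (0.33 log units) apart, within the scatter of two such steps. Among the compounds shown here, this gives no ground for saying that the change behaves differently on the two cores, but it does not show that the change carries over either: one step lies beyond the scatter and the other within it, each core offers only a single pair, and the two small steps cannot separate a real shift from repeat-to-repeat variation.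

The compounds shown leave open how the two cores differ in their own right, as the difference between them is not broken down into single changes here. They also leave open what happens in this assay when the nitrile on the phenyl ring is replaced by another group, such as an amine or a carboxylic acid, on either core.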